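Ortho chloro to methyl on a biphenyl amide

This account rests on a few compounds, and the source may have more. Where it says the series, first, only, none or still open, it means among the compounds named here.

Measured compounds:
compound 1 `Cc1ccccc1-c1cc(N2CCN(C)CC2)ccc1C(=O)N(C)Cc1cc(C(F)(F)F)cc(C(F)(F)F)c1` gives 1.4 nM in an assay on CHO cells for displacement of a labelled ligand from Substance-P receptor (Homo sapiens); a lower number here means a stronger inhibitor, a higher number a weaker inhibitor
compound 2 `CN(Cc1cc(C(F)(F)F)cc(C(F)(F)F)c1)C(=O)c1ccccc1-c1ccccc1Cl` gives 22 nM in this assay

Of the two compounds measured, compound 2 has the higher number in this assay, and its gap to compound 1 lies beyond the usual scatter. The two differ in more than one place, so their values alone say how far apart they sit, not which change carries the difference.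

Compound 3 `Cc1ccccc1-c1ccccc1C(=O)N(C)Cc1cc(C(F)(F)F)cc(C(F)(F)F)c1` has not yet been measured. It differs from compound 2 in one place only: methyl in place of chloro on an aromatic carbon. Within the data shown here, no pair of measured compounds separated by this single change is available, so the size of this step is not known from the data. Compound 1, which carries the methyl-substituted ring, has the lower number, but it also carries a further group that compound 3 lacks.

For compound 3 in this assay, a step of about a 1.6-fold lower number from compound 2 to compound 3 (0.20 log units; within the scatter) toward a somewhat lower number is expected, with a value around 14 nM and a range from 5 nM to 45 nM.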

Compound 3, inhibition constant: 17 nM
Beside the measured number, compound 3's estimate is 1.2-fold (0.08 log units) below it; the range from low to high includes it.
By their numbers in this assay, from the lowest: compound 1; then compounds 3 and 2 (each within the scatter of the next).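

In this assay, methyl in place of chloro on the aromatic carbon ortho to a large group gives a 1.3-fold lower number from compound 2 to compound 3 (0.11 log units; within the scatter) and so leaves the two compounds indistinguishable, which means that at this place the assay does not separate a 2-chlorophenyl from a 2-methylphenyl group. The other single change, hydrogen in place of 4-methylpiperazin-1-yl, gives a 12-fold higher number from compound 1 to compound 3 (1.08 log units; beyond the scatter) and is the only one of the two steps beyond the scatter, so among these compounds the large difference goes with the 4-methylpiperazin-1-yl group and not with the choice between chloro and methyl. Nothing measured on these compounds accounts for either step.

Going by these compounds, it remains open whether a different amine in that place, such as morpholine or a dimethylamino group, would go with a similarly large step, or whether a carboxylic acid would go the other way. Also open, on these data alone, is whether fluoro or methoxy on the aromatic carbon that carries chloro or methyl would match those two groups, and whether chloro and methyl would still match with 4-methylpiperazin-1-yl present.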